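The source may report more compounds than this note shows. Statements on the series, on what has been measured and on what is new or still open speak of the compounds shown alone.

The measured compounds, each in a functional assay on HCT-15 cells (Homo sapiens) for cytotoxicity, read by CCK-8 assay and cell counting, with a stated time of 72 h; a higher number here means a weaker inhibitor, a lower number a stronger inhibitor:
Compound 1 `COc1cc(OC)cc(-c2cc3ccccc3c(-c3cccc(O)c3)n2)c1` gives 840 nM.
Compound 2 `COc1cc(OC)cc(-c2cc3ccccc3c(-c3cccc(OC)c3)n2)c1` gives 1170 nM.
Compound 3 `COc1cc(OC)cc(-c2cc3ccccc3c(-c3cccc(N)c3)n2)c1` gives 4080 nM.

Among these three numbers compound 3 stands highest, that is, it is the weakest inhibitor of the set. Its distance to the others is clear: a 4.9-fold higher number from compound 1 to compound 3 (0.69 log units; beyond the scatter) and a 3.5-fold higher number from compound 2 to compound 3 (0.54 log units; beyond the scatter), both beyond the scatter, whereas a 1.4-fold higher number from compound 1 to compound 2 (0.14 log units; within the scatter) lies within it.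

Compound 4 `COc1cc(OC)cc(-c2cc3ccc(N(C)C)cc3c(-c3cccc(N)c3)n2)c1` differs from compound 3 in one place: dimethylamino in place of hydrogen on an aromatic carbon. Every measured step in this set concerns the group on the pendant phenyl ring, none of them touches the fused ring system. No measured step therefore bears on the change from compound 3 to compound 4, and what it will do in this assay cannot be read from the three numbers shown; all that is known is the starting point, the value of compound 3.

With nothing to anchor a direction, the step of a 1.4-fold lower number from compound 3 to compound 4 (0.13 log units; within the scatter) is estimated to be small, with a wide band around it. Compound 4 is accordingly expected to give about 3000 nM, with a range from 700 nM to 13000 nM.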

Compound 4, half-maximal inhibitory concentration: 2530 nM
For compound 4 the middle estimate is 1.2-fold (0.07 log units) above the measured one; the measured number falls inside the stated range.
By their numbers in this assay, from the lowest: compounds 1 and 2 (each within the scatter of the next); then compounds 4 and 3 (each within the scatter of the next).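

Going by these compounds alone, compound 4 is the first compound here changed on the fused ring system rather than on the pendant phenyl ring, and in this assay dimethylamino on an aromatic carbon, meta to a fused ring and para to a fused ring, gives a 1.6-fold lower number from compound 3 to compound 4 (0.21 log units; within the scatter) and so stays within the scatter. This aromatic carbon therefore carries dimethylamino in place of hydrogen without a change that this assay can separate from the scatter, at least with the amino group on the pendant ring that compounds 3 and 4 share. No measurement bearing on why the two numbers lie so close is available here.

The compounds shown leave open whether dimethylamino at this place would read the same with the hydroxy of compound 1 or the methoxy of compound 2 on the pendant ring. They also leave open whether a different group on this aromatic carbon, such as methoxy, a carboxylic acid or a morpholine ring, or dimethylamino on another carbon of the fused system, would move the number beyond the scatter.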